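The compounds below may be only part of what the source reports. "The series", "measured", "known", "first", "only" and "open" are said of these compounds alone.

Measured in a functional assay on MCF7 cells (Homo sapiens) for cytotoxicity, read by MTT assay, with a stated time of 96 h; on this read-out lower numbers stand for stronger inhibition and higher numbers for weaker inhibition:
compound 1 `COc1cc(C(=O)c2cn(-c3ccccc3)cc2-c2ccc(N)cc2)cc(OC)c1OC`: 9 nM
compound 2 `COc1cc(C(=O)c2cn(-c3ccccc3)cc2-c2ccccc2Br)cc(OC)c1OC`: 190 nM

Of these two numbers, compound 2 has the higher, 190 nM. Compound 3 `COc1cc(C(=O)c2cn(-c3ccccc3)cc2-c2ccc(Br)cc2)cc(OC)c1OC` has not yet been measured. It has 4-bromophenyl in place of 2-bromophenyl on an aromatic carbon of a five-membered aromatic ring with 1 nitrogen: 4-bromophenyl in place of 2-bromophenyl on an aromatic carbon. For the measured compounds named here, only one measured step bears on this change, and it is large: a 21-fold higher number from compound 1 to compound 2 (1.32 log units; beyond the scatter). That step alters both the substituent and its position, so the data cannot separate the two. Compound 3 shares the 4-substituted pattern of compound 1, which gives 9 nM, so a moderate move towards a lower number is expected, recovering only part of that gap. The expected change is a 3.8-fold lower number from compound 2 to compound 3 (0.58 log units; beyond the scatter). For compound 3 the estimated value is 50 nM, with an expected range of 12 nM to 200 nM.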

Compound 3, half-maximal inhibitory concentration: 340 nM
For compound 3 the middle estimate is 6.8-fold (0.83 log units) below the measured one; measured number above the stated range.
By their numbers in this assay, from the lowest: compound 1; then compounds 2 and 3 (each within the scatter of the next).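

In this assay, exchanging 2-bromophenyl for 4-bromophenyl gives a 1.8-fold higher number from compound 2 to compound 3 (0.25 log units; within the scatter), so the placing of the bromine on this phenyl ring makes no difference that can be told from scatter. The comparison that keeps the substituent's place and alters only the group gives a 38-fold higher number from compound 1 to compound 3 (1.58 log units; beyond the scatter), and this shows that the large gap separating compound 1 from the two bromo compounds goes with bromo in place of amino, which the earlier pair could not separate from position. Nothing measured here accounts for this gap.

Going by these compounds, it remains open whether the amine itself is needed, or whether a hydroxyl or a methylamino group in its place would also give a number close to that of compound 1. On these data alone, it is also open whether an amino group would tolerate the shift in position as bromo does.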